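Carbamate series: chain extension and metabolic half-life

This account rests on a few compounds, and the source may have more. Where it says the series, first, only, none or still open, it means among the compounds named here.

Compound 1 `CCCCCCCCCNC(=O)Oc1ccc(Cl)cc1C(=O)Nc1cccc(Cl)c1` and compound 2 `CCCCCCCCCCNC(=O)Oc1ccc(Cl)cc1C(=O)Nc1cccc(Cl)c1` share a core; in an ADME assay for metabolic stability, read by HPLC, at pH 7 (a lower number here means that the compound disappears faster, a higher number that the compound lasts longer), compound 1 gives 64 h and compound 2 gives 64 h. The change between them is methyl in place of hydrogen on a saturated chain carbon, nine bonds along the chain from an amide-type nitrogen, and the step of no change at the digits printed from compound 1 to compound 2 (within the scatter) lies within the scatter. Compound 3 `CCNC(=O)Oc1ccc(Cl)cc1C(=O)Nc1ccc(Cl)c(Cl)c1` carries a different core; how the two cores differ is not broken down here. In this assay compound 3 gives 64 h. Compound 4 `CCCNC(=O)Oc1ccc(Cl)cc1C(=O)Nc1ccc(Cl)c(Cl)c1` is not yet measured; it differs from compound 3 by methyl in place of hydrogen on a saturated chain carbon, two bonds along the chain from an amide-type nitrogen, the same kind of change as between compound 1 and compound 2, but placed two bonds along the chain from the amide-type nitrogen rather than nine bonds. The step from compound 3 to compound 4 is expected to be no change at the digits printed from compound 3 to compound 4 (within the scatter) in this assay, because no change at the digits printed from compound 1 to compound 2 (within the scatter) showed no change. Compound 4 is estimated at 64 h, between 30 h and 130 h.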

Compound 4, half-life: 64 h
For compound 4 middle estimate and measured number coincide at the digits printed, within the range that was stated.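

In this assay, methyl in place of hydrogen on a saturated chain carbon, two bonds along the chain from an amide-type nitrogen, gives no change at the digits printed from compound 3 to compound 4 (within the scatter). Set beside the earlier step, the change carries across the two cores without a detectable difference: the same change on two cores in this assay, no change at the digits printed (within the scatter) from compound 1 to compound 2 and no change at the digits printed (within the scatter) from compound 3 to compound 4, 1.0-fold (0.00 log units) apart, within the scatter of two such steps This rests on a single pair of steps, made at two different places on the chain, so it does not show that the change would read the same at other chain positions or on further cores.

Still open, from the compounds shown here alone, is whether an amine or a carboxylic acid carried on the chain would read differently in this assay. A ring in place of the chain also remains untested in the compounds shown.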